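From Compound 3 to Compound 4: A Shorter Linking Group

The source may report more compounds than this note shows. Statements on the series, on what has been measured and on what is new or still open speak of the compounds shown alone.

Of the compounds shown here, three sharing one core have been measured in a functional assay on L1210 cells (Mus musculus) for inhibition, read by MTT assay, with a stated time of 72 h; on this read-out higher numbers stand for weaker inhibition and lower numbers for stronger inhibition. Compound 1 `COc1cc(NC(C)CCCNC(=O)Nc2ccc(F)cc2)c2ncccc2c1` gives 18000 nM. Compound 2 `COc1cc(NC(C)CCCNC(=O)Nc2ccc(O)cc2)c2ncccc2c1`, carrying a hydroxy in place of fluoro on an aromatic carbon, gives 21000 nM, and the step between them was a 1.2-fold higher number from compound 1 to compound 2 (0.07 log units; within the scatter). Compound 3 `COc1cc(NC(C)CCCNC(=O)NNC(=O)Nc2cccc(Cl)c2)c2ncccc2c1` gives 27000 nM, the highest of the three numbers, yet its distances to the other two both fall within the scatter: the steps were a 1.5-fold higher number from compound 1 to compound 3 (0.18 log units; within the scatter) and a 1.3-fold higher number from compound 2 to compound 3 (0.11 log units; within the scatter), so nothing separates the three compounds beyond the noise of the measurement.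

Compound 4 `COc1cc(NC(C)CCCNC(=O)Nc2cccc(Cl)c2)c2ncccc2c1` has not yet been measured. It differs from compound 3 in one place: 3-chlorophenyl in place of ((3-chlorophenyl)carbamoyl)amino on an amide-type nitrogen. This reverses the kind of change seen in the steps to compound 3. In compound 1 and compound 2 the amide-type nitrogen likewise bears a single aromatic ring rather than the longer link. Those two steps were small and within the scatter, so their reversal is expected to bring only a small move, if any, in this assay, estimated as a 1.4-fold lower number from compound 3 to compound 4 (0.15 log units; within the scatter). Compound 4 is therefore expected to give 19000 nM, with a range from 9000 nM to 40000 nM.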

Compound 4, half-maximal inhibitory concentration: 17000 nM
Compound 4: middle estimate off by 1.1-fold (0.05 log units), on the high side, within the range that was stated.
By their numbers in this assay, from the lowest: compounds 4, 1, 2 and 3 (each within the scatter of the next).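

Among the compounds shown here, compound 4 gives the first clean test of the link itself, since in this assay the earlier steps to compound 3 changed the ring substituent along with the link, whereas here the 3-chlorophenyl ring stays and only the carbamoyl-amino portion goes (a 1.6-fold lower number from compound 3 to compound 4 (0.20 log units; within the scatter)). Going from 11 heavy atoms to 7 on the amide-type nitrogen, and from 2 hydrogen-bond donors and 1 acceptor to none in the changing group, therefore leaves the number within the scatter. With the short link now held constant, the ring can also be compared by itself, and the 3-chlorophenyl ring cannot be told apart from the 4-hydroxyphenyl ring (a 1.2-fold lower number from compound 2 to compound 4 (0.09 log units; within the scatter)) or the 4-fluorophenyl ring (a 1.1-fold lower number from compound 1 to compound 4 (0.02 log units; within the scatter)).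

No supporting data are available to explain why these steps stay so small. As far as these compounds go, all four numbers lie within the scatter of their neighbours, so it remains open whether an amine or a carboxylic acid on the aromatic ring, or a longer chain on the amide-type nitrogen in place of that ring, would move the number beyond the scatter.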